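Methoxy in place of hydrogen: compound 2 to compound 3

The compounds below may be only part of what the source reports. "The series", "measured", "known", "first", "only" and "open" are said of these compounds alone.

Within the data shown here, compound 2 `O=C(c1ccc2c(c1)OCCO2)N1N=C(c2ccccc2)CC1c1cccc(F)c1` holds the lowest of the two numbers measured so far. In a functional assay on WM 266-4 cells (Homo sapiens) for inhibition, read by MTT assay, with a stated time of 24 h (on this read-out lower numbers stand for stronger inhibition of growth and higher numbers for weaker inhibition of growth), compound 2 gives 1840 nM, while compound 1 `COc1ccc(C2=NN(C(=O)c3ccc4c(c3)OCCO4)C(c3ccc(F)cc3)C2)cc1` gives 3780 nM, a gap beyond the scatter; the two differ in more than one place, so no single change can be read from that pair. Compound 3 `COc1ccc(C2=NN(C(=O)c3ccc4c(c3)OCCO4)C(c3cccc(F)c3)C2)cc1` is not yet measured in this assay. It differs from compound 2 by methoxy in place of hydrogen on an aromatic carbon, the same difference read one bond further out as phenyl to 4-methoxyphenyl. Among the measured compounds shown here, no measured pair isolates this change. For the measured compounds named here, the only comparison available, compound 1 against compound 2, points toward a somewhat higher number, but it carries a second difference as well. A modest step upward, close to the edge of the scatter, is therefore expected from compound 2 to compound 3 a 1.4-fold higher number from compound 2 to compound 3 (0.15 log units; within the scatter). Compound 3 is estimated at 2600 nM, with a range from 1000 nM to 6500 nM.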

Compound 3, concentration for 50% growth inhibition: 930 nM
Estimate against measurement, compound 3: 2.8-fold (0.45 log units) above, and the stated range ends above it.
By their numbers in this assay, from the lowest: compounds 3 and 2 (each within the scatter of the next); then compound 1.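

In this assay, methoxy in place of hydrogen on an aromatic carbon, para to a large group, gives a 2.0-fold lower number from compound 2 to compound 3 (0.30 log units; within the scatter). Among these compounds, this is the first reading of the change on its own, and it shows that the 4-methoxyphenyl group is tolerated when the saturated ring carbon carries 3-fluorophenyl. With the 4-methoxyphenyl group held constant, 3-fluorophenyl in place of 4-fluorophenyl on that saturated ring carbon gives a 4.1-fold lower number from compound 1 to compound 3 (0.61 log units; beyond the scatter), a step beyond the scatter that compound 1 and compound 2 could not isolate. Nothing at hand bears on the origin of either step.

The compounds shown leave open whether the same fluorine change reads alike with phenyl in place of 4-methoxyphenyl. They also leave open how an amine, a carboxylic acid or ethoxy would read at the methoxy position.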